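Hydroxycarbamoyl in place of methoxycarbonyl: compound 3 to 4

The compounds below may be only part of what the source reports. "The series", "measured", "known", "first", "only" and "open" are said of these compounds alone.

Measured so far in a functional assay on HL-60 cells (Homo sapiens) for antiproliferative activity, tested at 20 uM; a lower number here means a weaker effect, a higher number a stronger effect of the compound at the concentration tested:
compound 1 `CC(=O)Oc1ccc(CONC(=O)c2ccc(CS(=O)(=O)Nc3ccc4cc(C)c(=O)n(C)c4c3)cc2)cc1` — compound 1 gives 0%
compound 2 `Cc1cc2cc(NS(=O)(=O)c3cc(C(=O)NO)ccc3Cl)ccc2n(C)c1=O` — compound 2 gives 32%
compound 3 `COC(=O)c1ccc(CS(=O)(=O)Nc2ccc3c(c2)cc(C)c(=O)n3C)cc1` — compound 3 gives 14%

Compound 3 stands second highest of the three numbers in this assay. Its nearest neighbour is compound 1, whose value lies lower by a gap beyond the scatter; the furthest is compound 2, whose value lies higher, again beyond the scatter. Among the measured compounds shown here, no pair of these three differs in only one place, so no single step is known.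

Compound 4 `Cc1cc2cc(NS(=O)(=O)Cc3ccc(C(=O)NO)cc3)ccc2n(C)c1=O` is not yet measured. It differs from compound 3 in one place: hydroxyamino in place of methoxy on a carbonyl carbon. Compound 2 carries the same hydroxycarbamoyl group and gives the highest of the three numbers, while compound 3 with methoxycarbonyl sits lower; on that basis an upward step of moderate size, beyond the scatter, is expected for a number 16 percentage points higher from compound 3 to compound 4 (beyond the scatter). For compound 4 the expected inhibition in this assay is 30%, with a range from 10% to 55%.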

Compound 4, a percentage reported as inhibition, at one concentration (the size of the read-out at that concentration, not a potency): 0%
Compound 4: the middle estimate sits 30 percentage points above what was measured, and the stated range ends above it.
By their numbers in this assay, from the lowest: compounds 1 and 4 (each within the scatter of the next); then compound 3; then compound 2.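

Within this assay the series now has its first readable single change: hydroxyamino in place of methoxy on a carbonyl carbon gives a number 14 percentage points lower from compound 3 to compound 4 (beyond the scatter) and the step runs downward. At this place, with an aromatic carbon as the other neighbour of the carbonyl carbon, hydroxycarbamoyl therefore brings no gain over methoxycarbonyl at the concentration tested. Nothing at hand bears on the reason for this step.

As far as these compounds go, it remains open whether a carboxylic acid or a plain carboxamide at this place would give a number nearer that of compound 3 or that of compound 4. Also open, from the compounds shown here alone, is whether an ethyl ester or a longer alkyl ester would hold the number of compound 3, and whether the same change runs in the same direction on another scaffold.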